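Removing the anilino methyl in a series of inactive chalcone-type amides

The compounds below may be only part of what the source reports. "The series", "measured", "known", "first", "only" and "open" are said of these compounds alone.

Measured compounds:
Compound 1, `Cc1ccc(Nc2nc(C)c(C(=O)/C=C/c3ccc(Cl)cc3)s2)cc1`. In a functional assay on PC-3 cells (Homo sapiens) for cytotoxicity, read by MTT assay (a lower number here means a stronger inhibitor, a higher number a weaker inhibitor), compound 1 gives > 25000 nM, a limit of the assay.
Compound 2, `Cc1ccc(Nc2nc(C)c(C(=O)/C=C/c3ccccc3)s2)cc1`. In this assay compound 2 gives > 25000 nM, again a limit.
Compound 3, `Cc1ccc(Nc2nc(C)c(C(=O)/C=C/c3ccccc3Cl)s2)cc1`. In this assay compound 3 gives > 25000 nM, also a limit.

Compound 1 stands at the limit of this assay, and the two other values sit at the same limit (the limit of > 25000 nM in this assay, at which 3 of the 3 values shown sit). Hence none of the measured steps can be read: a step that the two limits leave unreadable from compound 1 to compound 2, a step that the two limits leave unreadable from compound 1 to compound 3 and a step that the two limits leave unreadable from compound 2 to compound 3 are all unreadable in size, and no direction can be taken from them.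

The new compound is compound 4, `Cc1nc(Nc2ccccc2)sc1C(=O)/C=C/c1ccc(Cl)cc1`. It differs from compound 1 by hydrogen in place of methyl on an aromatic carbon, that is, 4-methylphenyl to phenyl on the shared core. The measured steps that bear on it are those above, all confined to the limit; they therefore give no evidence that a small change at the aromatic ring moves the value out of the limit, and a step of no readable size in this assay is the most that can be expected.

Compound 4 is accordingly expected to give about 40000 nM, with a range from 15000 nM to 150000 nM, most probably again reported only as a limit. For compound 4 this estimate means an expected step that the limit leaves unreadable from compound 1 to compound 4.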

Compound 4, half-maximal inhibitory concentration: > 25000 nM
Compound 4 ended at the assay's limit (the forecaster's own chance of this, stated with the estimate: 80%); the middle value lies beyond the limit too.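

Compound 4, like compound 1, gives only a limit in this assay, so the change from 4-methylphenyl to phenyl has no readable size and no new step can be read: the limit of > 25000 nM in this assay, at which 4 of the 4 values shown sit.

The compounds shown leave open whether any change on the shared core brings a value inside the measurable range of this assay at all.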